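The source may report more compounds than this note shows. Statements on the series, on what has been measured and on what is new or still open speak of the compounds shown alone.

Measured so far:
- compound 1, `COc1cc(-c2cc(/C=C/C(=O)c3ccc(N)cc3)[nH]n2)cc(OC)c1OC`: 98% in a functional assay on SK-OV-3 cells (Homo sapiens) for cytotoxicity, read by sulforhodamine B assay, with a stated time of 48 h, tested at 0.1 uM; on this read-out lower numbers stand for a stronger effect and higher numbers for a weaker effect at the one concentration tested
- compound 2, `COc1ccc(C(=O)/C=C/c2cc(-c3cc(OC)c(OC)c(OC)c3)n[nH]2)cc1`: 99% in this assay

Compound 2 gives the higher of the two numbers in this assay, but the gap to compound 1, a number 1 percentage points higher from compound 1 to compound 2 (within the scatter), is within the scatter, so the two read as one level: at this concentration neither compound does much to the cells.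

Compound 3, `COc1cc(-c2cc(/C=C/C(=O)c3ccc(F)c(F)c3)[nH]n2)cc(OC)c1OC`, is not yet measured. Its change from compound 2 is 3,4-difluorophenyl in place of 4-methoxyphenyl on a carbonyl carbon. Among the compounds with values here, the one measured step, from compound 1 to compound 2, also exchanged a substituent on this same aryl ring and left the read-out in this assay unchanged within the scatter. On that basis no step beyond the scatter is expected; the estimated step is a number 2 percentage points lower from compound 2 to compound 3 (within the scatter). Compound 3 is expected to give 97% in this assay, with a range from 85% to 105%.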

Compound 3, a percentage reported as activity, at one concentration (the size of the read-out at that concentration, not a potency): 99%
Compound 3: the middle estimate sits 2 percentage points below what was measured; the range from low to high includes it.
By their numbers in this assay, from the lowest: compounds 1, 2 and 3 (each within the scatter of the next).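

Putting 3,4-difluorophenyl in place of 4-methoxyphenyl on the carbonyl carbon gives no change at the digits printed from compound 2 to compound 3 (within the scatter) in this assay, and putting it in place of 4-aminophenyl gives a number 1 percentage points higher from compound 1 to compound 3 (within the scatter). This position therefore now carries three aryl groups at one level, and the level holds for a ring with two fluorines and no hydrogen-bond acceptor, whereas the earlier pair covered only rings with a single amino or methoxy substituent. No measurement is at hand that would explain this flat result.

With all three compounds at one level at the single concentration tested, the shown set does not tell whether these aryl groups would separate under other conditions. Also open, from the compounds shown here alone, is whether a carboxylic acid on this ring, or a longer chain in place of it, would move the read-out.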